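Cytotoxicity notes on the sulfoxide amide series, compound 4

This account rests on a few compounds, and the source may have more. Where it says the series, first, only, none or still open, it means among the compounds named here.

Values in an ADME assay on MT4 cells (Homo sapiens) for cytotoxicity, read by MTT assay, with a stated time of 5 days; a lower number here means that less compound is tolerated, a higher number that more compound is tolerated:
- compound 1 `COc1cc2nc(Nc3ccc(C#N)cc3)nc(Nc3c(Cl)cc(/C=C/C#N)cc3Cl)c2cc1OC`: 9920 nM
- compound 2 `COc1ccc(NC(=O)CSc2nc(Nc3c(C)cc(/C=C/C#N)cc3C)c3cc(OC)c(OC)cc3n2)cc1`: > 225000 nM, a limit of the assay and not a number
- compound 3 `COc1cc2nc([S+]([O-])CC(=O)Nc3ccc(Cl)cc3)nc(Nc3c(Cl)cc(/C=C/C#N)cc3Cl)c2cc1OC`: 14400 nM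

Compound 3 holds the higher of the two numbers, but the value of compound 1 sits within the scatter of it, so no order can be read between them. The single limit in the set is the limit of > 225000 nM in this assay, at which 1 of the 3 values shown sits.

Compound 4 `COc1cc2nc([S+]([O-])CC(=O)Nc3c(C)cc(C)cc3C)nc(Nc3c(Cl)cc(/C=C/C#N)cc3Cl)c2cc1OC` differs from compound 3 only in this change: 2,4,6-trimethylphenyl in place of 4-chlorophenyl on an amide-type nitrogen. Within the data shown here, no measured step in this assay tracks such a change, so the step from compound 3 to compound 4 is expected to be small, around the scatter, at a 1.2-fold higher number from compound 3 to compound 4 (0.07 log units; within the scatter). Compound 4 is estimated at 17000 nM, with a range of 6000 nM to 50000 nM.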

Compound 4, half-maximal cytotoxic concentration: 8870 nM
Compound 4: middle estimate off by 1.9-fold (0.28 log units), on the high side; measured number inside the range.
By their numbers in this assay, from the lowest: compounds 4, 1 and 3 (each within the scatter of the next). At a limit, above all of these: compound 2.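

In this assay, this amide nitrogen now has its first measured step: 2,4,6-trimethylphenyl in place of 4-chlorophenyl gives a 1.6-fold lower number from compound 3 to compound 4 (0.21 log units; within the scatter). The two aryl groups therefore cannot be told apart at this position, despite the loss of chlorine and the addition of three methyl groups. No evidence at hand bears on this step.

From the compounds shown here alone, it remains open whether a non-aryl group on this nitrogen, such as an aminoethyl chain or a carboxymethyl group, would give a step beyond the scatter.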